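This account rests on a few compounds, and the source may have more. Where it says the series, first, only, none or still open, it means among the compounds named here.

Compound 1 `Cc1cc(N2CC[C@@H](C)[C@@H](N(C)c3ncnc4[nH]ccc34)C2)n2nc(SCC3CCCCC3)nc2n1` gives 16300 nM in a functional assay on BGC-823 cells (Homo sapiens) for inhibition, read by MTT assay, with a stated time of 72 h; a lower number here means a stronger inhibitor, a higher number a weaker inhibitor.
Compound 2 `Cc1cc(N2CC[C@@H](C)[C@@H](N(C)c3ncnc4[nH]ccc34)C2)n2nc(SCc3cc(Cl)ccc3Cl)nc2n1` gives 18900 nM in this assay.
Compound 3 `C=CCSc1nc2nc(C)cc(N3CC[C@@H](C)[C@@H](N(C)c4ncnc5[nH]ccc45)C3)n2n1` gives 40900 nM in this assay.

All three compounds share one core and differ only in the group attached to a saturated chain carbon bound to a sulfur. Compound 3, carrying the smallest group there, stands at the highest number of the three, so it is the weakest inhibitor among them: a 2.5-fold higher number from compound 1 to compound 3 (0.40 log units; beyond the scatter) and a 2.2-fold higher number from compound 2 to compound 3 (0.34 log units; beyond the scatter), both modest but beyond the scatter. Between compound 1 and compound 2 the numbers are close, a 1.2-fold higher number from compound 1 to compound 2 (0.06 log units; within the scatter).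

Compound 4 `Cc1cc(N2CC[C@@H](C)[C@@H](N(C)c3ncnc4[nH]ccc34)C2)n2nc(SCc3ccc(Br)cc3)nc2n1` is the next compound. Its change from compound 3 is 4-bromophenyl in place of vinyl on a saturated chain carbon bound to a sulfur. Going by the values given here, the step that bears most directly on this is the one from compound 2 to compound 3, where a substituted phenyl gave way to vinyl and the number rose modestly. Going the other way, from vinyl to a substituted phenyl, a modest drop of roughly the same size is therefore expected, bringing compound 4 back toward the level of compound 1 and compound 2. The expected step is a 2.0-fold lower number from compound 3 to compound 4 (0.31 log units; beyond the scatter). Compound 4 is estimated at 20000 nM, within a range of 9000 nM to 45000 nM.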

Compound 4, half-maximal inhibitory concentration: 28000 nM
For compound 4 the middle estimate is 1.4-fold (0.15 log units) below the measured one, within the range that was stated.
By their numbers in this assay, from the lowest: compounds 1, 2, 4 and 3 (each within the scatter of the next, the first and the last beyond it).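

In this assay, exchanging vinyl for 4-bromophenyl gives a 1.5-fold lower number from compound 3 to compound 4 (0.16 log units; within the scatter), so this aromatic ring, unlike the 2,5-dichlorophenyl of compound 2, cannot be told apart from vinyl. Compound 4 also cannot be told apart from the two compounds with larger groups, with a 1.5-fold higher number from compound 2 to compound 4 (0.17 log units; within the scatter) and a 1.7-fold higher number from compound 1 to compound 4 (0.23 log units; within the scatter), so it goes against the earlier picture in which the vinyl compound stood clearly apart from every compound with a ring at this place. Nothing measured here explains why these four compounds fall as they do.

On these data alone, it remains open whether an amine, a carboxylic acid or a longer chain on this carbon would give a number beyond the scatter of these four. As far as these compounds go, it is also open whether any group at this place can reach a much lower number than compound 1, which gives 16300 nM.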